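Dichlorination on the phenyl tail of an acylamino core

This account rests on a few compounds, and the source may have more. Where it says the series, first, only, none or still open, it means among the compounds named here.

Three compounds share a thioxo-containing core carrying an amide side chain ending in a phenyl ring, and they were tested in an assay on membranes from brain for displacement of a labelled ligand from adenosine receptor A1 (Rattus norvegicus), read by scintillation counting, with a stated time of 90 min; a higher number here means a weaker inhibitor, a lower number a stronger inhibitor. Compound 1 `O=C(CCc1ccccc1)Nc1nc2ccccc2c(=O)s1` gives 422 nM, which is the higher of the two numbers reported. Compound 3 `COc1cccc(/C=C/C(=O)Nc2nc3ccccc3c(=O)s2)c1`, whose side chain carries an unsaturated linker and a methoxy-bearing phenyl, gives 205 nM, a lower number than compound 1 by a margin beyond the usual scatter. Compound 2 `Cc1sc2nc(NC(=O)CCCc3ccccc3)sc(=O)c2c1C`, built on a different core with two methyl groups and a longer chain, reaches only a limit of the assay, recorded as > 10000 nM, and this limit is the one noted in the limit of > 10000 nM in this assay, at which 1 of the 3 values shown sits.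

Compound 4 `O=C(CCc1ccc(Cl)c(Cl)c1)Nc1nc2ccccc2c(=O)s1` is compound 1 with one change: 3,4-dichlorophenyl in place of phenyl on a saturated chain carbon, two bonds along the chain from a carbonyl carbon. Among the compounds with values here, no measured pair shows this exact change, so the expectation rests on compound 1 alone. The step from compound 1 to compound 4 is expected to be modest and toward a lower number, a 1.7-fold lower number from compound 1 to compound 4 (0.23 log units; within the scatter), with a real chance of no shift beyond the scatter. Compound 4 is therefore estimated at 250 nM in this assay, within a range from 80 nM to 800 nM.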

Compound 4, inhibition constant: > 1500 nM
Compound 4 gave a limit, no number (the forecaster's own chance of this, stated with the estimate: 5%); at least 6.0-fold (0.77 log units) between middle value and limit.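

In this assay, within the data shown here, the pair of compound 1 and compound 4 gives the first direct reading of a change at the end of this chain: with the core and the saturated chain held constant, 3,4-dichlorophenyl in place of phenyl gives an at least 3.5-fold higher number from compound 1 to compound 4 (0.55 log units; beyond the scatter). The earlier compounds shown here differ from one another in more than one place, so none of them isolated the phenyl ring, whereas this pair shows that adding the two chlorines alone weakens binding. Compound 4 gives a limit and not a number, so the full size of the step stays unknown: the limit of > 1500 nM in this assay, at which 1 of the 4 values shown sits.

From the compounds shown here alone, whether both chlorines are needed for this loss stays open, and a single chlorine, a fluorine or a methyl group on the phenyl ring would help to separate these cases. Also open, going by these compounds, is whether 3,4-dichlorophenyl would act the same way on the unsaturated linker of compound 3.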